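From compound 1 to compound 4: a shorter chain

The compounds below may be only part of what the source reports. "The series", "measured", "known", "first", "only" and "open" are said of these compounds alone.

Measured so far in an ADME assay on PBMC cells (Homo sapiens) for cytotoxicity, with a stated time of 5 days (on this read-out lower numbers stand for stronger inhibition and higher numbers for weaker inhibition), for three compounds:
compound 1 `[N-]=[N+]=N[C@H]1C[C@H](n2cnc3c(NCCCCCO)nc(N)nc32)O[C@@H]1CO` gives > 100000 nM as a limit
compound 2 `CNc1nc(Cl)nc2c1ncn2[C@H]1C[C@H](N=[N+]=[N-])[C@@H](CO)O1` gives > 100000 nM as a limit
compound 3 `[N-]=[N+]=N[C@H]1C[C@H](n2cnc3c(N)nc(Cl)nc32)O[C@@H]1CO` gives 35800 nM as a number

Compound 1 sits at the limit of > 100000 nM in this assay, at which 2 of the 3 values shown sit, and so offers a limit, not a number, as the starting point. Compound 4 `[N-]=[N+]=N[C@H]1C[C@H](n2cnc3c(NCCO)nc(N)nc32)O[C@@H]1CO` keeps the core of compound 1 and changes only the chain, as follows: hydroxy in place of 3-hydroxypropyl on a saturated chain carbon, two bonds along the chain from a nitrogen on an aromatic ring in words, hydroxy in place of 3-hydroxypropyl on a saturated chain carbon, two bonds along the chain from a nitrogen on an aromatic ring. Read one bond further out, (5-hydroxypentyl)amino gives way to (2-hydroxyethyl)amino.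

Among the measured compounds shown here, no measured step touches this chain. For the measured compounds named here, the only step available, an at least 2.7-fold lower number from compound 2 to compound 3 (0.44 log units; beyond the scatter) for hydrogen in place of methyl on a nitrogen on an aromatic ring, lies elsewhere and bears on the change only loosely. It shows that a measurable value can occur on a closely related structure, and compound 3 is that case. No step beyond the scatter is therefore expected in this assay for the shorter chain. The expected change is a number no higher from compound 1 to compound 4 (the limit leaves the size open) as an estimate read against a limit. For compound 4 the estimated value is 100000 nM within an expected range of 40000 nM to 200000 nM in this read-out.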

Compound 4, half-maximal inhibitory concentration: > 100000 nM
Compound 4 was reported as a limit; the forecaster's own chance of this, stated with the estimate: 75%; the middle value sits exactly at the limit.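

In this assay, among the compounds shown here, compound 1 and compound 4 are both reported only as limits, so no step between them can be read, and both sit at the same limit: the limit of > 100000 nM in this assay, at which 3 of the 4 values shown sit. The compounds shown leave open whether going from (5-hydroxypentyl)amino to (2-hydroxyethyl)amino changes the value in this assay at all, and in which direction.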